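This account rests on a few compounds, and the source may have more. Where it says the series, first, only, none or still open, it means among the compounds named here.

Compound 1 `CCN(CC)S(=O)(=O)c1ccc(NC(=O)c2ccccc2)c2ccccc12`, compound 2 `O=C(Nc1ccc(S(=O)(=O)NC2CCCCC2)c2ccccc12)c1ccccc1` and compound 3 `CCOC(=O)N1CCC(NS(=O)(=O)c2ccc(NC(=O)c3ccccc3)c3ccccc23)CC1` share one core and were tested in an assay on L1.2 cells for binding affinity to C-C chemokine receptor type 8 (Homo sapiens); on this read-out higher numbers stand for weaker inhibition and lower numbers for stronger inhibition. In this assay compound 1 gives > 30000 nM, which is a limit of the assay and not a number (the limit of > 30000 nM in this assay, at which 1 of the 3 values shown sits). Compound 2 gives 4.4 nM, and compound 3 gives 0.17 nM, the lowest of the two numbers recorded, with compound 2 as its nearest neighbour. The step of an at least 6800-fold lower number from compound 1 to compound 2 (3.83 log units; beyond the scatter) and the step of a 26-fold lower number from compound 2 to compound 3 (1.41 log units; beyond the scatter) both alter the group on the sulfonamide nitrogen, leaving the rest of the molecule untouched. Compound 4 `CCOC(=O)N1CCC(NS(=O)(=O)c2ccc(NCCCc3ccccc3)c3ccccc23)CC1` changes a different part of compound 3: 3-phenylpropyl in place of benzoyl on a nitrogen on an aromatic ring. Neither measured step touches this nitrogen on the aromatic ring, and the measured compounds give no direct guide to the size of such a change. With no guide in hand, compound 4 is expected to show a 12-fold higher number from compound 3 to compound 4 (1.07 log units; beyond the scatter), a moderate rise carrying wide uncertainty. Compound 4 is therefore estimated at 2 nM, with a likely range from 0.2 nM to 20 nM.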

Compound 4, inhibition constant: 32.1 nM
For compound 4 the middle estimate is 16-fold (1.21 log units) below the measured one; measured number above the stated range.
By their numbers in this assay, from the lowest: compound 3; then compound 2; then compound 4. At a limit, above all of these: compound 1.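

In this assay, the nitrogen on the aromatic ring proves as sensitive as the sulfonamide nitrogen, with a 190-fold higher number from compound 3 to compound 4 (2.28 log units; beyond the scatter) for 3-phenylpropyl in place of benzoyl. Both groups carry one six-membered aromatic ring of carbon only, so an aromatic ring on this nitrogen does not by itself hold the number at the level of compound 3, although compound 4 still gives a measured 32.1 nM rather than a limit. No measured evidence shown here bears on what lies behind this step.

The step removes the carbonyl and alters the chain together, so the compounds shown do not separate the two. Still open, going by these compounds, is how 3-phenylpropanoyl, which keeps the carbonyl with a longer chain, or a shorter benzyl on this nitrogen would read.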